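The source may hold more compounds than are shown below. What is called first, only, known or untested is meant among the compounds shown, and "the series" means these compounds.

Among the measured compounds shown here, in a physicochemical assay for solubility, in phosphate buffer, measured as kinetic solubility, with a stated time of 1 h, at pH 7.4 (a higher number here means a more soluble compound, a lower number a less soluble compound), compound 2 `COc1ccc2nc(C)cc(OCC(=O)Nc3ccncc3)c2c1` gives 91500 nM, and compound 1 `COc1ccc(NC(=O)COc2cc(C)nc3ccc(OC)cc23)cc1` gives 108000 nM, so the two numbers sit within the usual scatter of each other; the only step seen so far, a 1.2-fold lower number from compound 1 to compound 2 (0.07 log units; within the scatter), was a swap of the group on the amide-type nitrogen. Compound 3 `COc1ccc2nc(C)cc(OCC(=O)NNC(=O)c3ccncc3)c2c1` has not been measured. It differs from compound 2 in that (((pyridin-4-yl)carbonyl)amino in place of pyridin-4-yl on an amide-type nitrogen). For the measured compounds named here, no measured step matches this change: the one known step on that nitrogen left the number essentially unchanged, but it exchanged one ring for another rather than inserting a further carbonyl and nitrogen. The expectation for compound 3 in this assay therefore rests on compound 2 alone and is an estimated step of a 1.0-fold higher number from compound 2 to compound 3 (0.02 log units; within the scatter), that is no shift beyond the scatter, with a wide range either way. Compound 3 is expected to give 95000 nM, with a likely range from 40000 nM to 200000 nM.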

Compound 3, solubility: >= 375000 nM
Compound 3: only a limit was reported; the forecaster's own chance of this, stated with the estimate: 20%; middle value at least 3.9-fold (0.59 log units) from the limit.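

The position on the amide-type nitrogen is not indifferent in this assay: the earlier ring swap stayed within the scatter, but placing ((pyridin-4-yl)carbonyl)amino there gives an at least 4.0-fold higher number from compound 2 to compound 3 (0.61 log units; beyond the scatter) and an at least 3.4-fold higher number from compound 1 to compound 3 (0.54 log units; beyond the scatter). So a change at this nitrogen can move the number beyond the scatter, and here the change keeps the pyridine ring while adding a carbonyl and a nitrogen. Compound 3 is reported only as a limit, so both steps give a minimum size: the limit of >= 375000 nM in this assay, at which 1 of the 3 values shown sits.

The compounds shown leave open whether the added carbonyl or the added nitrogen goes with the higher number, as compound 3 carries both at once. They also leave open what a longer chain ending in an amine or a carboxylic acid would give on this nitrogen.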